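A few compounds are considered here, and "the series" means these few. Any claim that something is new, unique, unknown or untested is made for them only; others in the source may bear on it.

Compound 1 `O=C(NO)c1ccc(-c2cn([C@H]3C[C@@H](CO)N(Cc4ccccc4)C3)nn2)cc1` gives < 10% in an assay on Sf9 cells for inhibition of histone deacetylase 11 (Homo sapiens), read by fluorescence, tested at 0.5 uM (on this read-out lower numbers stand for less inhibition and higher numbers for more inhibition at the one concentration tested (going by the name of the read-out)), which is a limit of the assay and not a number.
Compound 2 `O=C(NO)c1ccc(-c2cn([C@@H]3C[C@H](C(=O)O)N(Cc4ccccc4)C3)nn2)cc1` gives < 10% in this assay, again a limit of the assay.
Compound 3 `O=C(/C=C/c1cn([C@H]2C[C@@H](CO)N(Cc3ccccc3)C2)nn1)NO` gives 35% in this assay.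

Compound 1 therefore stands at the low end of what has been measured: its value is a limit, and compound 2 rests at the same limit, so the two cannot be ordered against each other. Among the compounds with values here, of the three, only compound 3 returns a number, and its core differs from that of compound 1 in more than one respect, so no single step between measured compounds can be drawn from it.

Compound 4 `O=C(NO)c1ccc(-c2cn([C@@H]3C[C@@H](CO)N(Cc4ccccc4)C3)nn2)cc1` remains to be measured in this assay. It differs from compound 1 as follows: the two compounds have the same atoms and bonds and differ only in configuration as drawn: 1 of 2 stereo elements differ; a stereocentre at a saturated ring carbon is drawn S in compound 1 and R in compound 4. Nothing measured here shows how such a change of configuration alone moves this read-out. Since compound 1 sits at the limit, as does compound 2 (the limit of < 10% in this assay, at which 2 of the 3 values shown sit), a fall beyond the scatter cannot be seen, and a rise beyond the scatter is not indicated by any step shown.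

Compound 4 is thus expected to give about 10% in this assay, within 0% to 25%, an expected step of a number no lower from compound 1 to compound 4 (the limit leaves the size open) that lies within the scatter.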

Compound 4, a percentage reported as inhibition, at one concentration (the size of the read-out at that concentration, not a potency): < 10%
Compound 4: no number, only a limit; the forecaster's own chance of this, stated with the estimate: 60%; the middle value sits exactly at the limit.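

Compound 4 gives < 10% in this assay, which is a limit of the assay and not a number. Compound 1 also rests at a limit, so no step can be read between compound 1 and compound 4: the limit of < 10% in this assay, at which 3 of the 4 values shown sit.

The compounds shown leave open whether changing a stereocentre at a saturated ring carbon from S to R moves this assay at all.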